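Hydrazone series: fluorine position on the benzylidene ring

The source may report more compounds than this note shows. Statements on the series, on what has been measured and on what is new or still open speak of the compounds shown alone.

Measured so far:
Compound 1, `O=C(N/N=C/c1ccccc1)c1cccnc1Nc1cccc(C(F)(F)F)c1` — 31%
Compound 2, `O=C(N/N=C/c1cccc(F)c1)c1cccnc1Nc1cccc(C(F)(F)F)c1` — 29.8%

Both numbers come from a functional assay on the whole organism (strain Wistar) for inhibition, with Rattus norvegicus as the target, read by paw edema, with a stated time of 4 h, at a dose of 10 mg/kg by the intraperitoneal route; a lower number here means less inhibition, a higher number more inhibition at the dose given (going by the name of the read-out). Compound 1 and compound 2 differ by a fluoro in place of hydrogen on an aromatic carbon, and the step is a number 1.2 percentage points lower from compound 1 to compound 2 (within the scatter). On the two numbers in hand, compound 2 stands at the lower of the two, with compound 1 nearest, but the gap between them is within the scatter, so no order between them can be read.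

Compound 3, `O=C(N/N=C/c1ccc(F)cc1)c1cccnc1Nc1cccc(C(F)(F)F)c1`, has not yet been measured in this assay. It differs from compound 2 as follows: 4-fluorophenyl in place of 3-fluorophenyl on a carbon with a double bond to nitrogen. For the measured compounds named here, no measured pair moves the fluorine from one position to another on this ring, so the one step that bears on it at all is that from compound 1 to compound 2, which was within the scatter. On that basis the expected step of a number 0.2 percentage points higher from compound 2 to compound 3 (within the scatter) is none beyond the scatter. Compound 3 is therefore estimated at 30%, in a range from 21% to 39%.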

Compound 3, a percentage reported as inhibition, in the whole organism at one dose (the size of the read-out at that dose, not a potency): 36.5%
For compound 3 the middle estimate is 6.5 percentage points below the measured one, and the stated range covers the measured number.
By their numbers in this assay, from the lowest: compounds 2, 1 and 3 (each within the scatter of the next).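

For the compounds shown here, this is the first pair that moves the fluorine on this ring: in this assay, 4-fluorophenyl in place of 3-fluorophenyl on the carbon with a double bond to nitrogen gives a number 6.7 percentage points higher from compound 2 to compound 3 (within the scatter), so this move does not separate the two compounds. The second fluoro placement also stays close to the unsubstituted ring, with a number 5.5 percentage points higher from compound 1 to compound 3 (within the scatter), which matches what the first fluoro placement showed. At this single dose, therefore, neither fluoro placement can be told apart from hydrogen or from the other. Nothing at hand bears on the reason for these numbers.

Still open, as far as these compounds go, is whether a larger change on this ring, such as a methoxy group, a dimethylamino group or a carboxylic acid, would move the inhibition of paw edema beyond the scatter. Also open, from the compounds shown here alone, is whether these three compounds would separate at another dose.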